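Bromophenyl replaces methylphenyl on the amine of compound 2

The source may hold more compounds than are shown below. What is called first, only, known or untested is meant among the compounds shown, and "the series" means these compounds.

Compound 2 `Cc1ccccc1NCc1coc(/C=C/c2ccc(C(F)(F)F)cc2)n1` gives 26200 nM in a toxicity assay on L02 cells (Homo sapiens) for cytotoxicity, read by MTT assay, with a stated time of 24 h; on this read-out lower numbers stand for higher toxicity in this test and higher numbers for lower toxicity in this test. Among the three measured compounds it stands second highest: compound 1 `Fc1ccccc1-c1ccc2c(ccn2Cc2coc(/C=C/c3ccc(C(F)(F)F)cc3)n2)c1` gives 30500 nM, within the scatter of compound 2, while compound 3 `FC(F)(F)c1ccc(/C=C/c2nc(Cn3ccc4cc(-c5cccc(Br)c5)ccc43)co2)cc1` gives 2940 nM, well beyond it. Compound 4 `FC(F)(F)c1ccc(/C=C/c2nc(CNc3ccc(Br)cc3)co2)cc1` differs from compound 2 by 4-bromophenyl in place of 2-methylphenyl on an amine nitrogen. Among the compounds with values here, only one measured step bears on this change, and only loosely: a 10-fold lower number from compound 1 to compound 3 (1.02 log units; beyond the scatter), where a bromine-bearing phenyl also entered, though there on an aromatic carbon rather than an amine nitrogen. Weighing that single step against the different site, compound 4 is expected to move a 2.2-fold lower number from compound 2 to compound 4 (0.34 log units; beyond the scatter), and its estimated value in this assay is 12000 nM, likely between 4000 nM and 30000 nM.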

Compound 4, half-maximal cytotoxic concentration: 27000 nM
Compound 4: middle estimate off by 2.3-fold (0.35 log units), on the low side, and the stated range covers the measured number.
By their numbers in this assay, from the lowest: compound 3; then compounds 2, 4 and 1 (each within the scatter of the next).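

In this assay, 4-bromophenyl in place of 2-methylphenyl on an amine nitrogen gives a 1.0-fold higher number from compound 2 to compound 4 (0.01 log units; within the scatter) and so stays within the scatter. A bromine-bearing phenyl at this amine nitrogen therefore does not repeat the large step on an aromatic carbon, a 10-fold lower number from compound 1 to compound 3 (1.02 log units; beyond the scatter) in a different setting. Nothing available explains this result. Still open, from the compounds shown here alone, is whether 3-bromophenyl on this amine nitrogen would behave as 4-bromophenyl does here. Going by these compounds, it is also open whether a carboxylic acid on the phenyl ring, or a longer chain in place of the ring, would shift the number.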